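From 2-Chlorobenzyl to 4-Fluorobenzyl on the Sulfur Side

A few compounds are considered here, and "the series" means these few. Any claim that something is new, unique, unknown or untested is made for them only; others in the source may bear on it.

Three compounds on a shared core were tested in a functional assay on the whole organism (artery, strain albino) with Rattus norvegicus as the target, with a stated time of 180 min, at a dose of 10 mg/kg by the oral route; a lower number here means less inhibition, a higher number more inhibition at the dose given (going by the name of the read-out). Compound 1 `COc1ccc(C2N=C(SCc3cccc(Cl)c3)NC(C)=C2C(=O)Nc2ccc(F)cc2)cc1OC` gives 13.4%, compound 2 `CC1=C(C(=O)Nc2ccc(F)cc2)C(c2ccc([N+](=O)[O-])cc2)N=C(SCc2cccc(Cl)c2)N1` gives 11.9%, and compound 3 `CC1=C(C(=O)Nc2ccc(Br)cc2)C(c2ccc(Cl)cc2Cl)N=C(SCc2ccccc2Cl)N1` gives 22.2%, the highest of the three numbers, within the scatter of compound 1 but beyond that of compound 2. Among the compounds with values here, the one measured step, a number 1.5 percentage points lower from compound 1 to compound 2 (within the scatter), lies within the scatter and does not touch the group bound to the sulfur. Compound 4 `CC1=C(C(=O)Nc2ccc(Br)cc2)C(c2ccc(Cl)cc2Cl)N=C(SCc2ccc(F)cc2)N1` differs from compound 3 by 4-fluorophenyl in place of 2-chlorophenyl on a saturated chain carbon bound to a sulfur. No measured step covers that position, so nothing shown speaks to its size. For compound 4 a step of a number 2.2 percentage points lower from compound 3 to compound 4 (within the scatter) is expected, not beyond the scatter. The value of compound 4 is estimated at 20%, from 8% to 32%.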

Compound 4, a percentage reported as inhibition, in the whole organism at one dose (the size of the read-out at that dose, not a potency): 28.4%
Beside the measured number, compound 4's estimate is 8.4 percentage points below it, within the range that was stated.
By their numbers in this assay, from the lowest: compounds 2, 1, 3 and 4 (each within the scatter of the next, the first and the last beyond it).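

Within the data shown here, this is the first measured step at the group on the sulfur: in this assay the exchange of 2-chlorobenzyl for 4-fluorobenzyl gives a number 6.2 percentage points higher from compound 3 to compound 4 (within the scatter) and so leaves no readable change on this background. The position therefore accepts this exchange of one benzyl group for another, although nothing here gives a reason for that result. The step changes both the halogen and its place on the ring, so 4-chlorobenzyl or 2-fluorobenzyl would be needed to separate the two. On these data alone, how a methyl group, a longer chain or a benzyl group bearing a carboxylic acid would fare at this position remains open.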